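Swapping a side group on the amide nitrogen

A few compounds are considered here, and "the series" means these few. Any claim that something is new, unique, unknown or untested is made for them only; others in the source may bear on it.

Results so far in an ADME assay on microsomes from liver (Mus musculus, strain CD-1) for metabolic stability, read by LC-MS, tested at 2 uM; on this read-out higher numbers stand for a longer-lived compound and lower numbers for a shorter-lived compound:
- Compound 1 `Cn1cc(CNC(=O)c2ccncc2Nc2cc(-c3ccc4ccn(C)c4c3)c3nccnc3c2)cn1` gives 0.267 h
- Compound 2 `CN1CC(NC(=O)c2ccncc2Nc2cc(-c3ccc4ccn(C)c4c3)c3nccnc3c2)CCC1=O` gives 0.75 h

Of these two, compound 2 has the longer half-life, at 0.75 h, and it is the comparison for compound 3 `CC(=O)N1CCOC(CNC(=O)c2ccncc2Nc2cc(-c3ccc4ccn(C)c4c3)c3nccnc3c2)C1`. On an amide-type nitrogen, compound 3 carries (4-acetylmorpholin-2-yl)methyl in place of 1-methyl-6-oxopiperidin-3-yl ((4-acetylmorpholin-2-yl)methyl in place of 1-methyl-6-oxopiperidin-3-yl on an amide-type nitrogen). Among the compounds with values here, one measured step bears on this place: a 2.8-fold higher number from compound 1 to compound 2 (0.45 log units; beyond the scatter). Within the data shown here, that step exchanged (1-methyl-1H-pyrazol-4-yl)methyl for 1-methyl-6-oxopiperidin-3-yl, and it shows only that a swap here can move the number modestly. The new swap keeps a six-membered non-aromatic ring, so a smaller move is expected. The expected change is a 1.3-fold lower number from compound 2 to compound 3 (0.10 log units; within the scatter), which stays within the scatter. For compound 3 the estimated half-life is 0.6 h, with an expected range from 0.25 h to 1.4 h.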

Compound 3, half-life: 0.217 h
Estimate against measurement, compound 3: 2.8-fold (0.44 log units) above, outside the stated range (below it).
By their numbers in this assay, from the lowest: compounds 3 and 1 (each within the scatter of the next); then compound 2.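

In this assay, the swap to (4-acetylmorpholin-2-yl)methyl gives a 3.5-fold lower number from compound 2 to compound 3 (0.54 log units; beyond the scatter) even though both groups contain a six-membered non-aromatic ring, so sharing that ring size does not preserve the half-life at this amide nitrogen. The other comparison gives a 1.2-fold lower number from compound 1 to compound 3 (0.09 log units; within the scatter) and stays within the scatter, which leaves compound 2 as the only one of the three clearly set apart, with 1-methyl-6-oxopiperidin-3-yl as its group. Nothing available explains why the half-life shifts with these groups.

This swap changes the ring, its attachment through a methyl link and the acetyl group all at once, so the compounds shown cannot assign the drop to any one of these. Also open, going by these compounds, is how the half-life would respond to a free amine or a carboxylic acid on the ring.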